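This account rests on a few compounds, and the source may have more. Where it says the series, first, only, none or still open, it means among the compounds named here.

Of the compounds shown here, three of a shared core have been measured in an assay on cells for antagonist activity at transmembrane domain-containing protein TMIGD3 (Homo sapiens), read by scintillation counting and cAMP accumulation; on this read-out lower numbers stand for stronger inhibition and higher numbers for weaker inhibition. Compound 1 `O=C(Nc1nccn2cc(-c3ccccc3)nc12)c1ccccc1` gives 163 nM. Compound 2 `O=C(c1ccccc1)N(C(=O)c1ccccc1)c1nccn2cc(-c3ccccc3)nc12`, which carries a second benzoyl on the amide-type nitrogen, gives 187 nM; the step of a 1.1-fold higher number from compound 1 to compound 2 (0.06 log units; within the scatter) lies within the scatter. Compound 3 `COc1ccc(C(=O)Nc2nc(-c3ccccc3)cn3cc(-c4ccccc4)nc23)cc1` gives 73 nM, the lowest of the three numbers; its gap to compound 1 and its gap to compound 2 both lie beyond the scatter, so compound 3 stands as the strongest inhibitor of the three.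

Compound 4 `O=C(Nc1nc(-c2ccccc2)cn2cc(-c3ccccc3)nc12)c1cccnc1` is the next compound, not yet measured in this assay. It differs from compound 3 in one place: pyridin-3-yl in place of 4-methoxyphenyl on a carbonyl carbon. The amide-type nitrogen and the rest of the core stay as in compound 3.

Among the measured compounds shown here, of the measured steps, only the step from compound 1 to compound 2 exists, and it concerns the amide-type nitrogen, not the aryl group on the carbonyl carbon; it therefore bears only loosely on the present change. For the measured compounds named here, no measured pair shows what an exchange of the aryl group on the carbonyl carbon does in this assay. With that absence of a guide, the estimated step of a 1.5-fold higher number from compound 3 to compound 4 (0.18 log units; within the scatter) is expected to stay close to the scatter, with a wide range. For compound 4 the expected value in this assay is 110 nM, estimated to fall between 40 nM and 300 nM.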

Compound 4, half-maximal inhibitory concentration: 172 nM
Beside the measured number, compound 4's estimate is 1.6-fold (0.19 log units) below it, within the range that was stated.
By their numbers in this assay, from the lowest: compound 3; then compounds 1, 4 and 2 (each within the scatter of the next).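

In this assay, among the compounds shown here, the exchange of 4-methoxyphenyl for pyridin-3-yl on a carbonyl carbon gives a 2.4-fold higher number from compound 3 to compound 4 (0.37 log units; beyond the scatter), the first measured change of the aryl group at this place. The step is modest, but unlike a 1.1-fold higher number from compound 1 to compound 2 (0.06 log units; within the scatter), which concerns the amide-type nitrogen, it lies beyond the scatter, so the number in this assay does respond to what sits on the carbonyl carbon, and in this single pair the 4-methoxyphenyl compound gives the lower number. No measured evidence accounts for the step, so the compounds shown give no explanation for it.

The single exchange replaces the whole aryl group at once, so the compounds shown cannot separate the loss of the methoxy group from the entry of the ring nitrogen, and they leave open how far a single pair can speak for this place in general. They also leave open what a plain phenyl, a 4-chlorophenyl, a 4-aminophenyl or a saturated piperidine ring on the same carbonyl carbon would give, with the rest of compound 3 kept unchanged.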